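The compounds below may be only part of what the source reports. "The series", "measured", "known", "first", "only" and "open" are said of these compounds alone.

Compound 2 `c1coc(CNCCCNc2ccnc3cc(-c4cccc5ccccc45)ccc23)c1` and compound 1 `COc1cccc(CNCCCNc2ccnc3cc(Cc4ccccc4)ccc23)c1O` have both been measured in an ADME assay for permeability, using PAMPA, with a stated time of 30 min, at pH 7.4; on this read-out lower numbers stand for lower permeability and higher numbers for higher permeability. Compound 2 gives 237 10^-6 cm/s, the higher of the two numbers, while compound 1 gives 23 10^-6 cm/s, a gap that lies beyond the usual scatter. Compound 3 `COc1cccc(CNCCCNc2ccnc3cc(-c4cccc5ccccc45)ccc23)c1O` has not yet been measured. It arises from compound 2 by a single change: 2-hydroxy-3-methoxyphenyl in place of furan-2-yl on a saturated chain carbon bound to an amine nitrogen. Within the data shown here, no measured pair shows exactly this exchange on the same core, so its effect cannot be read off directly. Still, compound 1 carries the same 2-hydroxy-3-methoxybenzyl group on the amine and gives 23 10^-6 cm/s, which suggests that a step downward in this assay is expected from compound 2 to compound 3, of size a 4.3-fold lower number from compound 2 to compound 3 (0.63 log units; beyond the scatter). Compound 3 is accordingly estimated at 55 10^-6 cm/s, with a plausible range from 18 10^-6 cm/s to 170 10^-6 cm/s.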

Compound 3, apparent permeability in the ADME assay: 237 10^-6 cm/s
Beside the measured number, compound 3's estimate is 4.3-fold (0.63 log units) below it; the measured number lies above the stated range.
By their numbers in the ADME assay, from the lowest: compound 1; then compounds 2 and 3 (each within the scatter of the next).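

In the ADME assay the exchange of furan-2-yl for 2-hydroxy-3-methoxyphenyl on a saturated chain carbon bound to an amine nitrogen gives no change at the digits printed from compound 2 to compound 3 (within the scatter) and so leaves the read-out unmoved at this position, despite the added hydrogen-bond donor, while in a physicochemical assay for acid dissociation, the same exchange gives no change at the digits printed from compound 2 to compound 3 (within the scatter) as well. In the physicochemical assay compound 2 gives 9.47 and compound 3 also gives 9.47 on this read-out. The large difference instead appears at the other place: in the ADME assay naphthalen-1-yl in place of benzyl on an aromatic carbon gives a 10-fold higher number from compound 1 to compound 3 (1.01 log units; beyond the scatter) with the 2-hydroxy-3-methoxybenzyl group held constant. Among these compounds, the low number of compound 1 therefore goes with its benzyl group, not with its amine substituent.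

As far as these compounds go, whether the amine position would remain as unresponsive with benzyl on the core, or with a carboxylic acid or a longer chain in place of these groups, stays open. Nothing shown here explains why the read-out follows one place and not the other.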